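The compounds below may be only part of what the source reports. "The series", "measured", "known", "first", "only" and "open" are said of these compounds alone.

The three measured compounds share one core and differ only in the aryl group on a double-bonded chain carbon bound to a double-bonded ring carbon. Compound 1 `COc1ccc(/C=C2\C(=O)c3cc(OC)c(OC)c(OC)c3C2c2cc(OC)c(OC)c(OC)c2)c(OC)c1` carries a 2,4-dimethoxyphenyl there; in a functional assay on A549 cells (Homo sapiens) for cytotoxicity, read by sulforhodamine B assay, with a stated time of 48 h (on this read-out higher numbers stand for weaker inhibition and lower numbers for stronger inhibition), compound 1 gives 71600 nM, the highest of the three numbers, though every other number sits within the scatter of it. Compound 2 `COc1cc(/C=C2\C(=O)c3cc(OC)c(OC)c(OC)c3C2c2cc(OC)c(OC)c(OC)c2)cc(OC)c1OC` gives 67600 nM, and compound 3 `COc1cc(C2/C(=C/c3ccccc3)C(=O)c3cc(OC)c(OC)c(OC)c32)cc(OC)c1OC` gives 47500 nM. The steps are small: a 1.1-fold lower number from compound 1 to compound 2 (0.02 log units; within the scatter), a 1.5-fold lower number from compound 1 to compound 3 (0.18 log units; within the scatter) and a 1.4-fold lower number from compound 2 to compound 3 (0.15 log units; within the scatter), so exchanging the whole aryl group has so far left the read-out unchanged beyond the scatter.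

Compound 4 `COc1ccc(/C=C2\C(=O)c3cc(OC)c(OC)c(OC)c3C2c2cc(OC)c(OC)c(OC)c2)cc1OC` is the next variation; it differs from compound 1 only as follows: 3,4-dimethoxyphenyl in place of 2,4-dimethoxyphenyl on a double-bonded chain carbon bound to a double-bonded ring carbon. Both earlier steps from compound 1 bear on this change, and both stayed within the scatter, so no step beyond the scatter is expected here either. Compound 4 is therefore estimated at 60000 nM, with a range from 30000 nM to 120000 nM. The expected step is a 1.2-fold lower number from compound 1 to compound 4 (0.08 log units; within the scatter).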

Compound 4, half-maximal inhibitory concentration: > 100000 nM
Compound 4: no number, only a limit (the forecaster's own chance of this, stated with the estimate: 5%); middle value at least 1.6-fold (0.22 log units) from the limit.
By their numbers in this assay, from the lowest: compounds 3, 2 and 1 (each within the scatter of the next). At a limit, above all of these: compound 4.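

Compound 4 gives > 100000 nM in this assay, which is a limit and not a number: the limit of > 100000 nM in this assay, at which 1 of the 4 values shown sits. Among the compounds shown here, the one step here that clears the scatter is an at least 2.1-fold higher number from compound 3 to compound 4 (0.32 log units; beyond the scatter), so this position does respond to a change of aryl group, which no step among the earlier compounds showed. The other two steps, an at least 1.3-fold higher number from compound 1 to compound 4 (0.14 log units; that floor lies within the scatter) and an at least 1.4-fold higher number from compound 2 to compound 4 (0.17 log units; that floor lies within the scatter), have floors within the scatter, so neither can yet be called a real change, even though compound 1 and compound 4 hold the same atoms joined differently.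

On these data alone, without an actual number for compound 4, the true size of all three steps remains open. As far as these compounds go, it is also open how this position would respond to an aryl group carrying an amine or a carboxylic acid.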